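The source may hold more compounds than are shown below. What is called first, only, known or untested is meant among the compounds shown, and "the series" means these compounds.

In a functional assay on MCF7 cells (Homo sapiens) for cytotoxicity, read by MTT assay, with a stated time of 72 h (on this read-out higher numbers stand for weaker inhibition and lower numbers for stronger inhibition), compound 2 (`COc1ncc(-c2ccc3nc(NC(=O)NC4CC4)nn3c2)cc1NS(=O)(=O)c1ccc(F)cc1`) gives 300 nM. Compound 1 (`COc1ncc(-c2ccc3nc(NC(=O)NCCN4CCCC4)nn3c2)cc1NS(=O)(=O)c1ccc(F)cc1`) gives 380 nM. Going by the values given here, these are the only two numbers so far, and they lie within the usual scatter of each other, so neither can be ranked above the other.

The next structure is compound 3 (`COc1ncc(-c2ccc3nc(NC(=O)NCCN4CCCCC4)nn3c2)cc1NS(=O)(=O)c1ccc(F)cc1`), which carries 2-(piperidin-1-yl)ethyl in place of cyclopropyl on an amide-type nitrogen.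

Among the compounds with values here, one measured step bears on this change: a 1.3-fold lower number from compound 1 to compound 2 (0.10 log units; within the scatter), where cyclopropyl replaces 2-(pyrrolidin-1-yl)ethyl on an amide-type nitrogen. That step runs in the opposite direction to the new one, and it stays within the scatter. The group entering compound 3 is 2-(piperidin-1-yl)ethyl rather than the 2-(pyrrolidin-1-yl)ethyl of compound 1, so the closest measured comparison is close but not identical. A single step is also thin evidence. In this assay, no change beyond the scatter is therefore expected, in either direction.

The estimated step is a 1.2-fold higher number from compound 2 to compound 3 (0.07 log units; within the scatter).

For compound 3, the expected value is 350 nM, with an estimated range of 150 nM to 800 nM.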

Compound 3, half-maximal inhibitory concentration: 200 nM
For compound 3 the middle estimate is 1.8-fold (0.24 log units) above the measured one, within the range that was stated.
By their numbers in this assay, from the lowest: compounds 3, 2 and 1 (each within the scatter of the next).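

In this assay, putting 2-(piperidin-1-yl)ethyl in place of cyclopropyl on the amide-type nitrogen gives a 1.5-fold lower number from compound 2 to compound 3 (0.18 log units; within the scatter) and so cannot be told apart from repeat-measurement noise; this position holds either a small carbon ring or a chain ending in a nitrogen-containing ring with no readable change in the number. Going by these compounds alone, compound 3 also adds the first comparison in which the chain stays the same and only the ring at its end differs: piperidin-1-yl in place of pyrrolidin-1-yl gives a 1.9-fold lower number from compound 1 to compound 3 (0.28 log units; within the scatter) and likewise stays within the scatter, so the size of that end ring has no readable effect here. Nothing measured in this set offers an explanation for these numbers.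

The compounds shown leave open whether a morpholine ring or a dimethylamino group at the end of the same chain, or a longer chain leading to the piperidin-1-yl ring, would move the number beyond the scatter. Within the data shown here, with every step so far inside the scatter, they also leave open whether any change at this position can shift the number by a readable amount.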